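This account rests on a few compounds, and the source may have more. Where it says the series, first, only, none or still open, it means among the compounds named here.

In a functional assay on MCF7 cells (Homo sapiens) for antiproliferative activity, read by MTT assay, with stated times of 24 h and 72 h (on this read-out higher numbers stand for weaker inhibition and lower numbers for stronger inhibition), compound 1 `COc1cc(N2C(=O)[C@@H](Oc3ccccc3)[C@H]2c2ccc(SC)cc2)cc(OC)c1OC` gives 7700 nM and compound 2 `COc1cc(N2C(=O)[C@@H](Oc3ccccc3)[C@H]2c2ccc([S+](C)[O-])cc2)cc(OC)c1OC` gives 20000 nM as the higher of the two numbers, so compound 2 is the weaker inhibitor so far. Compound 3 `COc1cc(N2C(=O)[C@@H](Oc3ccccc3)[C@H]2c2ccc(S(C)(=O)=O)cc2)cc(OC)c1OC` has not yet been measured. It carries methylsulfonyl on an aromatic carbon, para to a large group, and the change is a group of 4 heavy atoms (1 carbon, 2 oxygen, 1 sulfur; no ring) in place of a group of 3 heavy atoms (1 carbon, 1 oxygen, 1 sulfur; no ring), on an aromatic carbon. Among the measured compounds shown here, only one measured step bears on this: a 2.6-fold higher number from compound 1 to compound 2 (0.41 log units; beyond the scatter). That modest step also came with a larger group at this place, so a further modest rise in the number is expected in this assay, although a single step is thin evidence and a result within the scatter would be no surprise. The expected step is a 1.3-fold higher number from compound 2 to compound 3 (0.10 log units; within the scatter). For compound 3 the estimated value is 25000 nM with an expected range from 8000 nM to 70000 nM.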

Compound 3, half-maximal inhibitory concentration: 62000 nM
Beside the measured number, compound 3's estimate is 2.5-fold (0.39 log units) below it; low and high end bracket the measured number.
By their numbers in this assay, from the lowest: compound 1; then compound 2; then compound 3.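

Adding a further oxygen on the sulfur at this place weakens inhibition again in this assay, with a 3.1-fold higher number from compound 2 to compound 3 (0.49 log units; beyond the scatter) and so a second rise beyond the scatter. Across the whole change from methylsulfanyl to methylsulfonyl the loss adds up to an 8.1-fold higher number from compound 1 to compound 3 (0.91 log units; beyond the scatter) and leaves compound 3 as the weakest of the three. Among the compounds shown here, all three compounds therefore fall in one order, with the number climbing at each oxygen added to the sulfur and no compound going against that trend.

The compounds shown stop at sulfur groups, so it stays open how this position would respond to a group without sulfur, such as methoxy or an amine, or to a longer chain such as ethylsulfanyl. Why the number climbs also stays open, as no measurement here bears on the cause.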